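The source may hold more compounds than are shown below. What is called first, only, known or untested is meant among the compounds shown, and "the series" means these compounds.

In an ADME assay on 184B5 cells (Homo sapiens) for cytotoxicity, read by MTT assay, with a stated time of 72 h (on this read-out higher numbers stand for weaker inhibition of growth and lower numbers for stronger inhibition of growth), compound 1, with the structure `COc1ccc(CNc2nc([Se]C)nc3ccccc23)cc1`, gives only a limit of the assay, > 100000 nM. Compound 2, the structure `COc1ccc(CNc2nc([SeH])nc3ccccc23)cc1`, likewise reaches only a limit in this assay, > 100000 nM. Going by the values given here, the one step between them, a step that the two limits leave unreadable from compound 1 to compound 2, therefore cannot be sized. Compound 3, the structure `C[Se]c1nc([Se]C)c2cccnc2n1`, has no result in this assay: "not determined" (no result reported). So compound 2 stands at the point where measured numbers end, as the limit of > 100000 nM in this assay, at which 2 of the 3 values shown sit, shows.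

Compound 4, the structure `CSc1ccc(CNc2nc([SeH])nc3ccccc23)cc1`, differs from compound 2 in one place: methylsulfanyl in place of methoxy on an aromatic carbon. Among the compounds with values here, no measured step touches this kind of change, and the only measured step is unreadable, so there is no ground to expect a step in this assay beyond the scatter in either direction. Compound 4 is therefore expected to sit at about 100000 nM, within 30000 nM to 300000 nM, which is an estimated step of a number no higher from compound 2 to compound 4 (the limit leaves the size open), most likely reported again only as a limit.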

Compound 4, concentration for total growth inhibition: 86300 nM
The estimate for compound 4 lay 1.2-fold (0.06 log units) above the measured number; the measured number falls inside the stated range.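

With methylsulfanyl in place of methoxy at this position, para to a large group, this assay gives a number rather than a limit for the first time among these compounds. As far as these compounds go, the change amounts to an at least 1.1-fold lower number from compound 2 to compound 4 (0.06 log units; that floor lies within the scatter); this is only a floor, so the true size stays open and the step may be no larger than ordinary repeat variation. Compound 4 thus provides a first actual reading in a series whose other results stop at a limit: the limit of > 100000 nM in this assay, at which 2 of the 4 values shown sit.

The compounds shown leave open whether another group at this position, such as an amine, a chlorine atom or a longer chain like ethoxy, would give a number clearly apart from that limit. They also leave open whether the same swap would have a similar result in compound 1, which carries a methyl on the selenium.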